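The compounds below may be only part of what the source reports. "The series", "measured", "known", "first", "only" and "open" are said of these compounds alone.

Working notes on the series: in a functional assay on MDA-MB-435 cells (Homo sapiens) for inhibition (on this read-out lower numbers stand for stronger inhibition of growth and higher numbers for weaker inhibition of growth), compound 1 (`COc1cc(/C=C/C(=O)c2cccc(-n3cc(-c4ccc(Cl)cc4)[nH]c3=O)c2)cc(OC)c1OC`) gives 3630 nM and compound 2 (`COc1cc(/C=C/C(=O)c2cccc(-n3cc(-c4ccccc4)[nH]c3=O)c2)ccc1O`) gives 2140 nM as two values within the scatter of each other. Compound 3 (`COc1cc(/C=C/C(=O)c2cccc(-n3cc(-c4cc(OC)c(OC)c(OC)c4)[nH]c3=O)c2)cc(OC)c1OC`) has 3,4,5-trimethoxyphenyl in place of 4-chlorophenyl on an aromatic carbon of the core of compound 1 (3,4,5-trimethoxyphenyl in place of 4-chlorophenyl on an aromatic carbon). For the measured compounds named here, no measured pair isolates this change, so the data offer no direct guide to its size. In this assay the expected step stays within the scatter (a 1.5-fold lower number from compound 1 to compound 3 (0.16 log units; within the scatter)) with no firm direction. For compound 3 the estimated value is 2500 nM with an expected range from 700 nM to 9000 nM as the likely span.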

Compound 3, concentration for 50% growth inhibition: 2110 nM
Estimate against measurement, compound 3: 1.2-fold (0.07 log units) above; measured number inside the range.
By their numbers in this assay, from the lowest: compounds 3, 2 and 1 (each within the scatter of the next).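

In this assay, for the compounds shown here, 3,4,5-trimethoxyphenyl in place of 4-chlorophenyl, on an aromatic carbon of a five-membered aromatic ring with 2 nitrogen, gives a 1.7-fold lower number from compound 1 to compound 3 (0.24 log units; within the scatter) and is the first measured step at this position. This position therefore tolerates both aryl groups, and the exchange, which adds methoxy oxygens and removes chlorine, leaves the read-out within the scatter. No measurement shown offers an explanation for this result.

Still open, from the compounds shown here alone, is whether an amine or a carboxylic acid on this aryl ring would move the number beyond the scatter.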